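Swapping benzoyl for acetyl on the weakest of three compounds

This account rests on a few compounds, and the source may have more. Where it says the series, first, only, none or still open, it means among the compounds named here.

Measured compounds:
Compound 1, `N#C/C(=C\c1c(-c2ccccc2)[nH]c2ccccc12)C(=O)c1ccccc1`: 6300 nM
Compound 2, `CCOC(=O)C(=Cc1c(-c2ccccc2)[nH]c2ccccc12)C(=O)OCC`: 3800 nM
Compound 3, `O=C(/C(=C\c1c(-c2ccccc2)[nH]c2ccccc12)S(=O)(=O)c1ccccc1)c1ccccc1`: 39500 nM

All three compounds share the same core and were tested in a functional assay on Hs-578T cells (Homo sapiens) for inhibition, read by sulforhodamine B assay, with a stated time of 48 h; on this read-out higher numbers stand for weaker inhibition of growth and lower numbers for stronger inhibition of growth. Compound 3 stands at the highest number of the three. Its nearest neighbour is compound 1, whose number is lower by a gap that is beyond the usual scatter, and compound 2 sits lower still, also beyond the scatter. So compound 3 is the weakest inhibitor of growth among the three that have been measured.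

Compound 4, `CC(=O)/C(=C\c1c(-c2ccccc2)[nH]c2ccccc12)S(=O)(=O)c1ccccc1`, has not yet been measured. It differs from compound 3 in one place only: methyl in place of phenyl on a carbonyl carbon. Put more simply, the benzoyl group on the double-bonded chain carbon becomes an acetyl group.

Within the data shown here, no measured pair shows this kind of change, so the expectation rests on compound 3 alone and on the general size of the gaps seen among the other compounds. The step from compound 3 to compound 4 is expected to be small, estimated at a 1.3-fold lower number from compound 3 to compound 4 (0.12 log units; within the scatter), with no confident direction. Compound 4 is accordingly expected to give about 30000 nM, with a plausible range from 10000 nM to 90000 nM.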

Compound 4, concentration for 50% growth inhibition: 5000 nM
Estimate against measurement, compound 4: 6.0-fold (0.78 log units) above, outside the stated range (below it).
By their numbers in this assay, from the lowest: compounds 2, 4 and 1 (each within the scatter of the next); then compound 3.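

In this assay, trading benzoyl for acetyl gives a 7.9-fold lower number from compound 3 to compound 4 (0.90 log units; beyond the scatter), a step beyond the usual scatter, so the smaller group goes with clearly stronger inhibition of growth. Among these compounds, this shows that the group on this carbonyl carbon matters: the earlier compounds contain no pair that isolates such a change, and here replacing phenyl with methyl alone moves the result. Compound 4 keeps the phenylsulfonyl group of compound 3, so that group alone cannot account for the high number of compound 3, although nothing shown explains why the phenyl-to-methyl change has this effect.

The compounds shown leave open how the result changes between these two extremes, for example whether an ethyl group or a longer chain such as propyl on the carbonyl carbon would give a number closer to that of compound 4 or that of compound 3. They also leave open whether an amine in the same place would fit this picture, and whether the same swap would have a similar effect on a compound without the phenylsulfonyl group.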